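Phenyl to Tert-Butoxy on the Shared Core: Compound 4

The source may report more compounds than this note shows. Statements on the series, on what has been measured and on what is new or still open speak of the compounds shown alone.

Three compounds with one shared core have been measured in a functional assay on a cell-free system (plasma, Homo sapiens), with a stated time of 3 min; a higher number here means a weaker inhibitor, a lower number a stronger inhibitor:
compound 1 `CC1(C[C@@H](O)C(=O)N2N=CC[C@H]2C(=O)NCc2cc(Cl)ccc2-n2cnnn2)CC1` gives 730 nM
compound 2 `CC(C)(C)C[C@@H](O)C(=O)N1N=CC[C@H]1C(=O)NCc1cc(Cl)ccc1-n1cnnn1` gives 590 nM
compound 3 `O=C(NCc1cc(Cl)ccc1-n1cnnn1)[C@@H]1CC=NN1C(=O)[C@H](O)Cc1ccccc1` gives 1400 nM

Compound 3 carries the highest number of the three. Its nearest neighbour in number is reached by the step of a 1.9-fold higher number from compound 1 to compound 3 (0.28 log units; within the scatter), which lies within the scatter, while the step of a 2.4-fold higher number from compound 2 to compound 3 (0.38 log units; beyond the scatter) lies beyond it and counts as modest. So far, then, the phenyl compound reads no stronger than either of the two compounds without an aromatic ring.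

Compound 4 `CC(C)(C)OC[C@@H](O)C(=O)N1N=CC[C@H]1C(=O)NCc1cc(Cl)ccc1-n1cnnn1` differs from compound 3 in one place: tert-butoxy in place of phenyl on a saturated chain carbon, two bonds along the chain from a carbonyl carbon and an oxygen on a saturated carbon. Within the data shown here, the steps that bear on this change are the two that already replace phenyl by a group without a ring, a 1.9-fold higher number from compound 1 to compound 3 (0.28 log units; within the scatter) and a 2.4-fold higher number from compound 2 to compound 3 (0.38 log units; beyond the scatter). Both point the same way: the phenyl compound shows the higher number. Tert-butoxy, like tert-butyl, has no ring, so the expected direction is a lower number for compound 4 than for compound 3, at about the size of those two steps. Among the measured compounds shown here, no measured step brings an oxygen acceptor into this place, so the estimate is kept wide. Compound 4 is estimated at 800 nM, with a range from 350 nM to 1800 nM, which means an expected step of a 1.8-fold lower number from compound 3 to compound 4 (0.24 log units; within the scatter).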

Compound 4, half-maximal inhibitory concentration: 750 nM
Compound 4: middle estimate off by 1.1-fold (0.03 log units), on the high side, within the range that was stated.
By their numbers in this assay, from the lowest: compounds 2, 1, 4 and 3 (each within the scatter of the next, the first and the last beyond it).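

In this assay, the step of a 1.3-fold higher number from compound 2 to compound 4 (0.10 log units; within the scatter) and the step of a 1.0-fold higher number from compound 1 to compound 4 (0.01 log units; within the scatter) both lie within the scatter, so tert-butoxy, with its one hydrogen-bond acceptor, cannot be told apart from tert-butyl or 1-methylcyclopropyl at this place on the saturated chain carbon. The step of a 1.9-fold lower number from compound 3 to compound 4 (0.27 log units; within the scatter) lies within the scatter as well, which means that compound 4 cannot be separated from the phenyl compound either, and the step of a 2.4-fold higher number from compound 2 to compound 3 (0.38 log units; beyond the scatter) remains the only one among these four compounds that lies beyond it. Bringing an oxygen into this group therefore leaves the number inside the band already set by the other three groups, and no measurement at hand offers a reason for these readings.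

The compounds shown leave open whether a group carrying an amine or a carboxylic acid at this place, or a longer chain, would move the number beyond the scatter in either direction. They also leave open how phenoxy would read, since that group would combine the aromatic ring of compound 3 with the oxygen of compound 4.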